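Thiazolidinedione benzimidazole amides: pyrrolidine to oxazolylamino

This account rests on a few compounds, and the source may have more. Where it says the series, first, only, none or still open, it means among the compounds named here.

Two compounds of this series have numbers in a functional assay on PC-3 cells (Homo sapiens) for inhibition, read by MTT assay, with a stated time of 48 h; on this read-out lower numbers stand for stronger inhibition and higher numbers for weaker inhibition. Compound 1 `Cn1c(/C=C2\SC(=O)N(CC(=O)Nc3cc(C(C)(C)C)on3)C2=O)nc2ccccc21` returns only a limit of the assay in this assay, > 50000 nM. Compound 2 `CC(C)n1c(/C=C2\SC(=O)N(CC(=O)N3CCCC3)C2=O)nc2ccccc21` likewise gives only a limit in this assay, > 50000 nM. Compound 2 therefore stands at the limit of > 50000 nM in this assay, at which 2 of the 2 values shown sit, and nothing in the shown data separates it from compound 1; both values show the same limit and no order between them.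

Compound 3 `CC(C)n1c(/C=C2\SC(=O)N(CC(=O)Nc3cc(C(C)(C)C)on3)C2=O)nc2ccccc21` is not yet measured. It differs from compound 2 in one place: (5-(tert-butyl)-1,2-oxazol-3-yl)amino in place of pyrrolidin-1-yl on a carbonyl carbon. For the measured compounds named here, no measured pair carries this exact change, so no step size is recorded for it. Since compound 1 already carries the entering (5-(tert-butyl)-1,2-oxazol-3-yl)amino group and sits at the limit > 50000 nM, no gain beyond the scatter is expected from the exchange, and the step from compound 2 to compound 3 is estimated as a step that the limit leaves unreadable from compound 2 to compound 3. Compound 3 is therefore expected to give about 60000 nM in this assay, within 20000 nM to 200000 nM, most likely again as a limit.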

Compound 3, half-maximal inhibitory concentration: > 50000 nM
Compound 3 gave a limit, no number (the forecaster's own chance of this, stated with the estimate: 75%); the middle value is on the limit's open side.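

In this assay compound 3 returns only a limit, as do compound 1 and compound 2, so the steps to compound 3 from both cannot be read: (the limit of > 50000 nM in this assay, at which 3 of the 3 values shown sit). On these data alone, whether the exchanges of pyrrolidin-1-yl or methyl have any effect on a readable value in this assay remains open.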